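Tert-butyl in place of benzyl on the amide nitrogen

The source may hold more compounds than are shown below. What is called first, only, known or untested is meant among the compounds shown, and "the series" means these compounds.

Among the measured compounds shown here, compound 2 `C[C@H](NC(=O)[C@]1(Cc2ccccc2)CCN1C(=O)OCc1ccccc1)C(=O)NCc1ccccc1` is the one member of this set with a numerical result: in an ADME assay on HELF cells (Homo sapiens) for cytotoxicity, with a stated time of 3 days (on this read-out lower numbers stand for higher toxicity in this test and higher numbers for lower toxicity in this test), compound 2 gives 42000 nM. Compound 1 `C[C@H](NC(=O)[C@@]1(Cc2ccccc2)CCN1C(=O)OCc1ccccc1)C(=O)NC(C)(C)C` reaches only a limit of the assay, > 100000 nM. This is the limit of > 100000 nM in this assay, at which 1 of the 2 values shown sits. Compound 3 `C[C@H](NC(=O)[C@]1(Cc2ccccc2)CCN1C(=O)OCc1ccccc1)C(=O)NC(C)(C)C` has not been measured; it differs from compound 2 by tert-butyl in place of benzyl on an amide-type nitrogen. Compound 3 is expected to shift toward lower toxicity, by a 2.1-fold higher number from compound 2 to compound 3 (0.33 log units; beyond the scatter). In this assay compound 3 is estimated at 90000 nM, ranging from 40000 nM to 200000 nM, with a fair chance that only a limit is reported.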

Compound 3, half-maximal cytotoxic concentration: > 100000 nM
Compound 3: only a limit was reported; the forecaster's own chance of this, stated with the estimate: 55%; middle value at least 1.1-fold (0.04 log units) from the limit.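

Tert-butyl in place of benzyl on an amide-type nitrogen gives, in this assay, an at least 2.3-fold higher number from compound 2 to compound 3 (0.37 log units; beyond the scatter), so this position moves the read-out toward lower toxicity in this test. Compound 3 gives > 100000 nM, which is a limit of the assay and not a number: the limit of > 100000 nM in this assay, at which 2 of the 3 values shown sit. The step between the two compounds at that limit cannot be read, so it shows nothing about the drawn configuration at the saturated ring carbon: the fact that compounds 1 and 3 differ only in the configuration as drawn The compounds shown leave open how large the step from benzyl to tert-butyl really is. They also leave open whether a longer chain or a carboxylic acid on this nitrogen would give a readable value.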